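This account rests on a few compounds, and the source may have more. Where it says the series, first, only, none or still open, it means among the compounds named here.

Of the compounds shown here, two have been read so far in a functional assay on HepG2 cells (Homo sapiens) for inhibition, read by MTT assay, with a stated time of 72 h; a higher number here means a weaker inhibitor, a lower number a stronger inhibitor. In that assay compound 1 `C=C(c1ccc(Cl)c(Cl)c1)C1COC2(CCCCC2)OO1` gives 83500 nM. Compound 2 `C=C(c1ccc(F)c(F)c1)C1COC(C)(C)OO1` gives > 100000 nM, which is a limit of the assay and not a number. Compound 3 `C=C(c1ccc(OC)c(F)c1)C1COC(C)(C)OO1` differs from compound 2 in one place: it has methoxy in place of fluoro on an aromatic carbon, ortho to a fluoro group and para to a large group (methoxy in place of fluoro on an aromatic carbon). Among the measured compounds shown here, no measured pair shows what this change does, so the expectation is a cautious one. Weak inhibition is expected to persist, as the only numeric reading is that of compound 1 at 83500 nM. The estimated step of an at least 1.1-fold lower number from compound 2 to compound 3 (0.04 log units; that floor lies within the scatter) in this assay is expected to stay within the scatter, in neither direction beyond it. For compound 3 the estimated value is 90000 nM, with an expected range from 35000 nM to 200000 nM.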

Compound 3, half-maximal inhibitory concentration: > 100000 nM
Compound 3: no number, only a limit; the forecaster's own chance of this, stated with the estimate: 50%; at least 1.1-fold (0.04 log units) between middle value and limit.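

Compound 2 and compound 3 both end at a limit of the assay and not at a number, so no step can be read between them: the limit of > 100000 nM in this assay, at which 2 of the 3 values shown sit. Going by these compounds, what methoxy in place of fluoro on an aromatic carbon does in this assay stays open.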